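Dichloro versus monochloro purine cores: notes on compound 4

The source may report more compounds than this note shows. Statements on the series, on what has been measured and on what is new or still open speak of the compounds shown alone.

Measured so far:
compound 1 `ClCc1ccccc1Cn1cnc2c(Cl)nc(Cl)nc21` — 1620 nM
compound 2 `ClCc1cccc(Cn2cnc3ncnc(Cl)c32)c1` — 5370 nM
compound 3 `ClCc1ccccc1Cn1cnc2ncnc(Cl)c21` — 19100 nM

In a functional assay on PC-3 cells (Homo sapiens) for cytotoxicity, read by sulforhodamine B assay, with a stated time of 48 h (on this read-out higher numbers stand for weaker inhibition of growth and lower numbers for stronger inhibition of growth), compound 2 gives 5370 nM, the second highest of the three numbers. Compound 1 sits beyond the scatter below it, and compound 3 sits beyond the scatter above it, so compound 2 is clearly separated from both neighbours.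

Compound 4 `ClCc1cccc(Cn2cnc3nc(Cl)nc(Cl)c32)c1` is not yet measured. It differs from compound 2 by chloro in place of hydrogen on an aromatic carbon. The same contrast in the core is seen between compound 1 and compound 3: compound 1, with the second chloro group, gives 1620 nM, while compound 3 gives 19100 nM, a markedly lower number for the dichloro core. Among the measured compounds shown here, no counted step between those two is available, so this is read only as what the two values show.

On that basis the step from compound 2 to compound 4 is expected to lower the number well beyond the scatter, with a 7.7-fold lower number from compound 2 to compound 4 (0.88 log units; beyond the scatter) as the estimate. Compound 4 is therefore expected near 700 nM in this assay, within a range from 200 nM to 2500 nM.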

Compound 4, concentration for total growth inhibition: 2880 nM
Beside the measured number, compound 4's estimate is 4.1-fold (0.61 log units) below it; the whole stated range lies below it.
By their numbers in this assay, from the lowest: compounds 1, 4 and 2 (each within the scatter of the next, the first and the last beyond it); then compound 3.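

In this assay, among the compounds shown here, chloro in place of hydrogen on an aromatic carbon between two ring nitrogen atoms gives a 1.9-fold lower number from compound 2 to compound 4 (0.27 log units; within the scatter), the first counted step at this position. The earlier pair with the same contrast in the core shows a wide gap in its printed values, with compound 1 at 1620 nM and compound 3 at 19100 nM, whereas the step in this pair stays within the scatter, so the gap seen in the earlier pair does not carry over to this one. Nothing available here bears on why the same change reads differently in the two pairs.

Only hydrogen and chloro are shown at this position, so the outcome with an amine, a methoxy group or a longer chain there remains open. On these data alone, the two pairs also differ in where the chloromethyl group sits on the other aromatic ring, and with one pair for each placement, it remains open whether that placement governs the size of the step.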